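The compounds below may be only part of what the source reports. "The series", "measured", "known", "first", "only" and "open" are said of these compounds alone.

Measured so far in a functional assay on MCF7 cells (Homo sapiens) for cytotoxicity, read by sulforhodamine B assay, with a stated time of 48 h; a higher number here means a weaker inhibitor, a lower number a stronger inhibitor:
compound 1 `COc1ccc(/C=C/C(=O)c2ccc(NC(C)=O)c(-c3ccc(F)cc3)c2)cc1OC` gives 15000 nM
compound 2 `COc1ccc(/C=C/C(=O)c2ccc(N)c(-c3ccc(F)cc3)c2)cc1OC` gives 15000 nM

Compound 2 stands level with compound 1 at the digits shown, and compound 1 is also its nearest neighbour. Among the compounds with values here, only one measured step exists, no change at the digits printed from compound 1 to compound 2 (within the scatter), and it lies within the scatter. That step puts hydrogen in place of acetyl on a nitrogen on an aromatic ring, so the nitrogen stays.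

Compound 3 `COc1ccc(/C=C/C(=O)c2cccc(-c3ccc(F)cc3)c2)cc1OC` goes further, with hydrogen in place of amino on an aromatic carbon. This is hydrogen in place of amino on an aromatic carbon, and here the nitrogen itself leaves. Within the data shown here, the measured step touches the same site and is the only guide, but it does not test the loss of the nitrogen. Its size, no change at the digits printed from compound 1 to compound 2 (within the scatter), therefore gives only a weak reason to expect little movement in this assay, and no direction can be drawn from it. The expected step is no change at the digits printed from compound 2 to compound 3 (within the scatter), with no shift beyond the scatter anticipated. For compound 3 the estimated value is 15000 nM, with an expected range from 6000 nM to 38000 nM.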

Compound 3, half-maximal inhibitory concentration: 11600 nM
For compound 3 the middle estimate is 1.3-fold (0.11 log units) above the measured one, within the range that was stated.
By their numbers in this assay, from the lowest: compounds 3, 1 and 2 (each within the scatter of the next).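

In this assay, the loss of the nitrogen itself, with hydrogen in place of amino on the aromatic carbon ortho to a 4-fluorophenyl group, gives a 1.3-fold lower number from compound 2 to compound 3 (0.11 log units; within the scatter) and so leaves the read-out within the scatter. The earlier pair had shown only that the acetyl group could leave while the nitrogen stayed, whereas the wider change, hydrogen in place of acetamido, gives a 1.3-fold lower number from compound 1 to compound 3 (0.11 log units; within the scatter) and is also within the scatter, so this assay does not separate acetamido, amino and hydrogen at this position. No evidence is available that bears on why these three compounds cannot be told apart here.

The compounds shown leave open whether a carboxylic acid, a methoxy group or a longer chain on this aromatic carbon would move the number beyond the scatter. They also leave open whether the same indifference to the group at this site would hold if the 4-fluorophenyl group were replaced by a hydrogen atom or by a pyridine.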